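A few compounds are considered here, and "the series" means these few. Any claim that something is new, unique, unknown or untested is made for them only; others in the source may bear on it.

Measured so far in a functional assay on K562 cells (Homo sapiens) for antiproliferative activity; on this read-out higher numbers stand for weaker inhibition of growth and lower numbers for stronger inhibition of growth:
Compound 1 `COCCCCCCCCCCCCCCC/C=C1/CC(CO)(COC(=O)C(C)(C)C)OC1=O` gives 0.138 ug/mL
Compound 2 `CC(C)(C)C(=O)OCC1(CO)C/C(=C\CCCCCCCCCCCO)C(=O)O1` gives 1.09 ug/mL
Compound 3 `CC(C)(C)C(=O)OCC1(CO)C/C(=C\CCCCCCCCCCCCCCC=O)C(=O)O1` gives 5.11 ug/mL

Compound 3 has the highest number of the three and so shows the weakest inhibition of growth, with compound 2 nearest to it and compound 1 furthest away. The change to compound 4 (`CC(C)(C)C(=O)OCC1(CO)C/C(=C/CCCCCCCCCCCCCCC=O)C(=O)O1`) is this: the two compounds have the same atoms and bonds; at least one stereo element is drawn with a configuration in one of them and without one in the other: 1 of 2 stereo elements differ; a double bond is drawn E in compound 3 and Z in compound 4 and nothing else, with a double bond drawn E in compound 3 and Z in compound 4. Among the measured compounds shown here, no measured step covers such a change. For the measured compounds named here, the only step available, a 4.7-fold higher number from compound 2 to compound 3 (0.67 log units; beyond the scatter), is modest and concerns 3-formylpropyl in place of hydroxy, not the drawing of the double bond. It shows that numbers in this assay can move beyond the scatter within this small set, but it gives no direction here. No step beyond the scatter is therefore expected, although the range is kept wide. The estimated step is a 1.1-fold lower number from compound 3 to compound 4 (0.06 log units; within the scatter) and it stays within the scatter. For compound 4 the expected value is 4.5 ug/mL with an estimated range from 1.5 ug/mL to 13 ug/mL.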

Compound 4, concentration for 50% growth inhibition: 2.58 ug/mL
For compound 4 the middle estimate is 1.7-fold (0.24 log units) above the measured one; measured number inside the range.
By their numbers in this assay, from the lowest: compound 1; then compound 2; then compounds 4 and 3 (each within the scatter of the next).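

In this assay the drawing of the double bond is now tested directly, and a 2.0-fold lower number from compound 3 to compound 4 (0.30 log units; within the scatter) leaves the two compounds unseparated, so with formyl on the chain this change does not move the number beyond the scatter. The group on the saturated chain carbon does move it: formyl in place of methoxymethyl gives a 19-fold higher number from compound 1 to compound 4 (1.27 log units; beyond the scatter) on that carbon. The reading of the double bond carries one qualification: the fact that one of compounds 3 and 4 is drawn with a defined configuration and the other without, at the place where they differ.

On these data alone, whether the drawing of the double bond counts the same way with methoxymethyl or hydroxy on the chain stays open. So does what this assay would show for a carboxylic acid or an amine in place of formyl on that chain carbon.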